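The source may hold more compounds than are shown below. What is called first, only, known or untested is meant among the compounds shown, and "the series" means these compounds.

In a functional assay on MCF7 cells (Homo sapiens) for cytotoxicity, read by MTT assay, with a stated time of 72 h (on this read-out higher numbers stand for weaker inhibition and lower numbers for stronger inhibition), compound 2 `COc1ccc(/C=C2\CCC/C(=C\c3ccc(OC)c(OC)c3)C2=O)cc1` gives 7800 nM and compound 1 `COc1ccc(/C=C2\CCC/C(=C\c3cccc(Br)c3)C2=O)cc1OC` gives 5300 nM, so the two values lie within the usual scatter of each other. Compound 3 `COc1ccc(/C=C2\CCC/C(=C\c3cccc(Cl)c3Cl)C2=O)cc1OC` has not yet been measured. It differs from compound 2 in one place, on a double-bonded chain carbon bound to a double-bonded ring carbon: 2,3-dichlorophenyl in place of 4-methoxyphenyl on a double-bonded chain carbon bound to a double-bonded ring carbon. Among the compounds with values here, only one measured step bears on this change. It was made at that same place, where 4-methoxyphenyl replaced 3-bromophenyl, and it amounts to a 1.5-fold higher number from compound 1 to compound 2 (0.17 log units; within the scatter). Within the data shown here, compound 3 returns a halogen-bearing phenyl to this carbon, although with chlorine rather than bromine, and no measured compound carries that exact group. No change beyond the scatter is therefore expected in this assay, in either direction, and the expected step is a 1.4-fold lower number from compound 2 to compound 3 (0.15 log units; within the scatter). For compound 3 the estimated value is 5500 nM, with an expected range from 2200 nM to 13000 nM.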

Compound 3, half-maximal inhibitory concentration: 14300 nM
Compound 3: the middle estimate sits 2.6-fold (0.41 log units) below what was measured; measured number outside the range, above it.
By their numbers in this assay, from the lowest: compounds 1, 2 and 3 (each within the scatter of the next, the first and the last beyond it).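

In this assay, within the data shown here, the carbon in question now carries three different groups, and the first step beyond the scatter appears: a 2.7-fold higher number from compound 1 to compound 3 (0.43 log units; beyond the scatter), with 2,3-dichlorophenyl in place of 3-bromophenyl, a modest loss of inhibition. A halogen-bearing phenyl therefore does not by itself settle the number here, since the two halogen-bearing compounds stand apart, while a 1.8-fold higher number from compound 2 to compound 3 (0.26 log units; within the scatter) keeps the change from 4-methoxyphenyl within the scatter. Nothing measured explains why these two halogen-bearing groups differ. The compounds leave open whether the second chlorine or the chlorine-for-bromine exchange accounts for the step, which a phenyl bearing a single chlorine could help to separate. As far as these compounds go, how this carbon would respond to a phenyl carrying an amine or a carboxylic acid also remains open.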